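The compounds below may be only part of what the source reports. "The series", "measured", "known", "first", "only" and "open" are said of these compounds alone.

So far, two compounds have been tested in an ADME assay on Vero cells (Chlorocebus sabaeus) for cytotoxicity; on this read-out lower numbers stand for higher toxicity in this test and higher numbers for lower toxicity in this test: compound 1 `CC(c1ccc(OC(F)(F)F)cc1)N1CCC2(CC1)CN(c1nc(=O)c3cc(C(F)(F)F)cc([N+](=O)[O-])c3s1)C2` and compound 2 `CC(c1cc(F)cc(F)c1)N1CC2(CCN(c3nc(=O)c4cc(C(F)(F)F)cc([N+](=O)[O-])c4s3)CC2)C1`. Compound 1 gives > 64 ug/mL, which is a limit of the test and not a number. Compound 2 gives > 64 ug/mL, which is also a limit and not a number. Compound 2 therefore stands at the limit of > 64 ug/mL in this assay, at which 2 of the 2 values shown sit. Within the data shown here, neither compound has an exact reading, so no measured step is available to show how large a change to expect.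

Compound 3 `CC(c1ccc(OC(F)(F)F)cc1)N1CC2(CCN(c3nc(=O)c4cc(C(F)(F)F)cc([N+](=O)[O-])c4s3)CC2)C1` differs from compound 2 in one place: 4-(trifluoromethoxy)phenyl in place of 3,5-difluorophenyl on a saturated chain carbon bound to an amine nitrogen in a ring and a saturated chain carbon. In words, it has 4-(trifluoromethoxy)phenyl in place of 3,5-difluorophenyl on a saturated chain carbon bound to an amine nitrogen in a ring and a saturated chain carbon. Each group contains one six-membered aromatic ring of carbon only and carries no net charge.

No change beyond the usual scatter is expected in this assay, and this expectation rests on compound 2, with its limit of > 64 ug/mL. The estimated step is a number no higher from compound 2 to compound 3 (the limit leaves the size open). For compound 3 the expected reading is 64 ug/mL, with an estimated range of 32 ug/mL to 128 ug/mL.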

Compound 3, half-maximal cytotoxic concentration: > 64 ug/mL
Compound 3: a limit, no number; the forecaster's own chance of this, stated with the estimate: 85%; the middle value lies on the limit itself.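

Compound 2 and compound 3 both sit at a limit of this assay, not at a number, and no step can be read between them. The compounds shown leave open how far 4-(trifluoromethoxy)phenyl in place of 3,5-difluorophenyl moves this read-out, and at what concentration any of them would reach half-maximal cytotoxicity, with all readings at one point: the limit of > 64 ug/mL in this assay, at which 3 of the 3 values shown sit.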